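The compounds below may be only part of what the source reports. "The series", "measured", "known", "first", "only" and "open" are said of these compounds alone.

Of the compounds shown here, three ending in a selenium-linked nitrile have been tested in a functional assay on HepG2 cells (Homo sapiens) for inhibition, read by MTT assay, with a stated time of 48 h; a higher number here means a weaker inhibitor, a lower number a stronger inhibitor. Compound 1 `COc1ccc(N(C)c2nc(C)nc3ccccc23)cc1OCCCCCC[Se]C#N` is the weakest of the three at 4890 nM. Compound 2 `Cc1nc(N(C)c2ccc(OCC[Se]C#N)cc2)c2ccccc2n1` gives 1680 nM, and compound 3 `Cc1nc(N(C)c2ccc([Se]C#N)c(Cl)c2)c2ccccc2n1` gives a far lower 12 nM.

Compound 4 `COc1ccc(N(C)c2nc(C)nc3ccccc23)cc1OCCCC[Se]C#N` has not yet been measured. It differs from compound 1 in one place: a group of 3 heavy atoms (1 carbon, 1 nitrogen, 1 selenium; no ring) in place of a group of 5 heavy atoms (3 carbon, 1 nitrogen, 1 selenium; no ring), on a saturated chain carbon, four bonds along the chain from an oxygen on an aromatic ring, on a saturated chain carbon, four bonds along the chain from an oxygen on an aromatic ring. Among the compounds with values here, no measured pair isolates this change, so any forecast rests on thin evidence. The closest hint is that compound 1 has a longer chain than compound 2, and compound 2 gives a lower number of 1680 nM, although its core also differs from that of compound 1.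

A small move toward stronger inhibition therefore seems most likely, and it may well stay within the scatter. The expected step is a 1.5-fold lower number from compound 1 to compound 4 (0.18 log units; within the scatter). The estimated value for compound 4 is 3200 nM, within an expected range of 1300 nM to 7500 nM.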

Compound 4, half-maximal inhibitory concentration: 6460 nM
Estimate against measurement, compound 4: 2.0-fold (0.31 log units) below; measured number inside the range.
By their numbers in this assay, from the lowest: compound 3; then compound 2; then compounds 1 and 4 (each within the scatter of the next).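

In this assay, within the data shown here, this is the first pair of compounds that differ in only one place. On a saturated chain carbon, four bonds along the chain from an oxygen on an aromatic ring, a group of 3 heavy atoms in place of a group of 5 heavy atoms gives a 1.3-fold higher number from compound 1 to compound 4 (0.12 log units; within the scatter), so the two compounds cannot be told apart. No measurement shown here offers an explanation for this result.

From the compounds shown here alone, whether a longer chain, or a sulfur-linked nitrile in place of the selenium-linked one, would give a step beyond the scatter on this core remains open. No single-place step connects compound 2 or compound 3 to this pair, so the compounds shown do not reveal which structural difference accounts for their lower numbers.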